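Carboxy to morpholinylcarbonyl on an inactive indole scaffold

A few compounds are considered here, and "the series" means these few. Any claim that something is new, unique, unknown or untested is made for them only; others in the source may bear on it.

Of the compounds shown here, two have been tested in an assay on isolated protein for inhibition of Amine oxidase [flavin-containing] A (Homo sapiens), read by fluorescence, with stated times of 30 min and 1 h; a lower number here means a stronger inhibitor, a higher number a weaker inhibitor. Compound 1 `COc1ccc2c(c1)cc(CNCc1ccccc1)n2C` gives > 100000 nM; 100000 nM (2 entries) in this assay, values that record no measurable inhibition (the several entries of compound 1 in this assay, > 100000 nM; 100000 nM (2 entries)). Compound 2 `Cn1c(C(=O)O)cc2cc(OCCCC3CCN(Cc4ccccc4)CC3)ccc21` is recorded only as a limit of this assay, > 100000 nM, so no number stands for it (the limit of > 100000 nM in this assay, at which 1 of the 2 values shown sits). Within the data shown here, no step between measured compounds can be drawn from these entries.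

Compound 3 `Cn1c(C(=O)N2CCOCC2)cc2cc(OCCCC3CCN(Cc4ccccc4)CC3)ccc21` has not yet been measured in this assay. It differs from compound 2 in one place: morpholin-4-yl in place of hydroxy on a carbonyl carbon. With both measured compounds showing no inhibition, no direction of change can be inferred from the data; an estimated step of an at least 1.2-fold lower number from compound 2 to compound 3 (0.09 log units; that floor lies within the scatter) is given only as a neutral expectation. Compound 3 is therefore expected to give about 80000 nM in this assay, within a range of 10000 nM to 300000 nM, and it is likely that only a limit will again be reported.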

Compound 3, half-maximal inhibitory concentration: > 100000 nM
Compound 3: only a limit was reported (the forecaster's own chance of this, stated with the estimate: 75%); at least 1.2-fold (0.09 log units) between middle value and limit.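

In this assay compound 3 gives > 100000 nM, which is a limit of the assay. Among these compounds, compound 2 also stands only at a limit, and no step between compound 2 and compound 3 can be read. The compounds shown leave open whether any group on this carbonyl carbon gives measurable inhibition.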